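The source may hold more compounds than are shown below. What is called first, only, known or untested is meant among the compounds shown, and "the series" means these compounds.

Measured compounds:
compound 1, `O=C(Nc1ccc2[nH]ncc2n1)[C@H]1CCCN1C(=O)C1(c2ccc(F)cc2)CCC1`, 0.126 nM in an assay on isolated protein for inhibition of histone acetyltransferase p300 (Homo sapiens), with a stated time of 60 min; on this read-out higher numbers stand for weaker inhibition and lower numbers for stronger inhibition
compound 2, `O=C(Nc1ccc2[nH]c(=O)[nH]c2c1)[C@H]1CCCN1C(=O)C1(c2cccc(Cl)c2)CCCC1`, 0.398 nM

On this assay compound 2 stands as the higher of the two numbers, and compound 1 lies below it by a gap beyond the scatter. Compound 3, `O=C(Nc1cnc2[nH]ncc2c1)[C@H]1CCCN1C(=O)C1(c2cccc(Cl)c2)CCCC1`, differs from compound 2 by a group of 9 heavy atoms (6 carbon, 3 nitrogen; one five-membered aromatic ring with 2 hetero atoms, one six-membered aromatic ring with 1 hetero atom) in place of a group of 10 heavy atoms (7 carbon, 2 nitrogen, 1 oxygen; one five-membered aromatic ring with 2 hetero atoms, one six-membered aromatic ring of carbon only), on an amide-type nitrogen. The group that enters resembles the group carried by compound 1, whose value is the lower of the two, so a step downward of modest size is expected: a 2.0-fold lower number from compound 2 to compound 3 (0.30 log units; within the scatter). Compound 3 is therefore estimated at 0.2 nM, within the range 0.08 nM to 0.5 nM.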

Compound 3, half-maximal inhibitory concentration: 15.9 nM
Estimate against measurement, compound 3: 80-fold (1.90 log units) below; the measured number lies above the stated range.
By their numbers in this assay, from the lowest: compound 1; then compound 2; then compound 3.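

The group on the amide-type nitrogen proves to be a sensitive place: in this assay, replacing one group with another of nearly the same size gives a 40-fold higher number from compound 2 to compound 3 (1.60 log units; beyond the scatter). The entering group has 1 hydrogen-bond donor and 2 hydrogen-bond acceptors, against 2 donors and 1 acceptor in the group that leaves, with the rest of the molecule unchanged. Nothing given here accounts for the size of this step.

The compounds shown leave open which part of the exchange carries the step. They also leave open how a phenyl group carrying an amine would read on that nitrogen.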